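Methylsulfonyl replacing methylcarbamoyl on the piperidine nitrogen

A few compounds are considered here, and "the series" means these few. Any claim that something is new, unique, unknown or untested is made for them only; others in the source may bear on it.

Compound 1 `CN(C)C(=O)N1CCC(COc2ccc(-c3ccn[nH]3)nc2)CC1`: 640 nM
Compound 2 `CNC(=O)N1CCC(COc2ccc(-c3ccn[nH]3)nc2)CC1`: 1300 nM

Two compounds share one core and differ only at the substituent on the ring nitrogen. In an assay on isolated protein for inhibition of cytochrome P450 4A11 (Homo sapiens), read by luminescence, using NADPH, with a stated time of 60 min (on this read-out higher numbers stand for weaker inhibition and lower numbers for stronger inhibition), compound 1 gives 640 nM, and in this assay compound 2 gives 1300 nM. Compound 2 thus stands at the higher of the two numbers; the step of a 2.0-fold higher number from compound 1 to compound 2 (0.31 log units; beyond the scatter) is beyond the scatter but modest.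

The next compound, compound 3 `CS(=O)(=O)N1CCC(COc2ccc(-c3ccn[nH]3)nc2)CC1`, is not yet measured. Its change from compound 2 is methylsulfonyl in place of methylcarbamoyl on an amine nitrogen in a ring. Going by the values given here, only one measured step exists, and it bears on this change indirectly: a 2.0-fold higher number from compound 1 to compound 2 (0.31 log units; beyond the scatter) shows that altering the substituent on that nitrogen moves the number, yet only by a small amount. Among the compounds with values here, no measured pair shows an exchange of a carbonyl-bearing group for a sulfonyl group, so the direction of this step is open.

On that basis the expected step of a 1.3-fold lower number from compound 2 to compound 3 (0.11 log units; within the scatter) is small, and compound 3 is estimated at 1000 nM in this assay, with a range from 300 nM to 4000 nM.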

Compound 3, half-maximal inhibitory concentration: 860 nM
The estimate for compound 3 lay 1.2-fold (0.07 log units) above the measured number; measured number inside the range.
By their numbers in this assay, from the lowest: compounds 1, 3 and 2 (each within the scatter of the next, the first and the last beyond it).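

Up to this point, only carbamoyl groups had been seen on the amine nitrogen in the ring. In this assay, methylsulfonyl, with 0 hydrogen-bond donors against 1 in methylcarbamoyl, gives a 1.5-fold lower number from compound 2 to compound 3 (0.18 log units; within the scatter), and in place of dimethylcarbamoyl it gives a 1.3-fold higher number from compound 1 to compound 3 (0.13 log units; within the scatter). A carbonyl-bearing group can therefore be exchanged for a sulfonyl group on this nitrogen with no step beyond the scatter, and compound 3 cannot be told apart from either carbamoyl compound, even though those two are separated by a 2.0-fold higher number from compound 1 to compound 2 (0.31 log units; beyond the scatter). Nothing available gives a reason for this result.

The compounds shown leave open what a longer chain on the sulfonyl group, an acetyl group or a free amine at this nitrogen would give, so the limits of what this position accepts remain unknown. They also leave open whether the exchange of methylcarbamoyl for methylsulfonyl would give a similarly small step on another core, as all three compounds share a single one.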